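The compounds below may be only part of what the source reports. "The series", "measured", "known", "first", "only" and "open" are said of these compounds alone.

Three compounds share one core and were tested in a functional assay on MCF7 cells (Homo sapiens) for antiproliferative activity, read by MTT assay, with a stated time of 72 h; a higher number here means a weaker inhibitor, a lower number a stronger inhibitor. Compound 1 `Cc1cc(NCCN(C)C)nc2ccc(NC(=O)c3ccc(Cl)c(Cl)c3)cc12` gives 2550 nM. Among the measured compounds shown here, compound 3 `Cc1cc(N2CCN(C(C)C)CC2)nc2ccc(NC(=O)c3ccc(Cl)c(Cl)c3)cc12` gives 1710 nM, and the only one-place step among the measured compounds is a 1.5-fold lower number from compound 1 to compound 3 (0.17 log units; within the scatter), which swaps the side chain on the core. Compound 2 `CCN1CCN(c2cc(C)c3cc(NC(=O)c4ccc(Br)cc4)ccc3n2)CC1` gives 5940 nM, the highest of the three numbers, which makes it the weakest inhibitor here, since its gaps to compound 1 and compound 3 both lie beyond the scatter.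

Compound 4 `CCN1CCN(c2cc(C)c3cc(NC(=O)c4ccc(OC)cc4)ccc3n2)CC1` differs from compound 2 in one place: methoxy in place of bromo on an aromatic carbon. For the measured compounds named here, no measured step touches this part of the molecule; the step of a 1.5-fold lower number from compound 1 to compound 3 (0.17 log units; within the scatter) concerns the other end of the core, so it gives no guide to the direction here. With no comparable change to lean on, a step of uncertain direction is expected, and a wide range is used. Compound 4 is expected to give 8000 nM, between 2500 nM and 25000 nM, so the expected step is a 1.3-fold higher number from compound 2 to compound 4 (0.13 log units; within the scatter).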

Compound 4, half-maximal inhibitory concentration: 7690 nM
Estimate against measurement, compound 4: 1.0-fold (0.02 log units) above, and the stated range covers the measured number.
By their numbers in this assay, from the lowest: compounds 3 and 1 (each within the scatter of the next); then compounds 2 and 4 (each within the scatter of the next).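

In this assay, the change from 4-bromophenyl to 4-methoxyphenyl gives a 1.3-fold higher number from compound 2 to compound 4 (0.11 log units; within the scatter), so at this place, para to a large group, bromo and methoxy cannot be told apart. Among the compounds shown here, this is the first reading at this place, since the one earlier step concerned only the side chain of the shared core. No measurement at hand accounts for this result.

As far as these compounds go, whether an amine, a carboxylic acid or a longer chain such as ethoxy at this place would move the number beyond the scatter remains open. From the compounds shown here alone, it also remains open whether the side chain of compound 1 would read the same when combined with the bromo group of compound 2 or the methoxy group of compound 4.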